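Chloro in place of hydrogen on compound 1

A few compounds are considered here, and "the series" means these few. Any claim that something is new, unique, unknown or untested is made for them only; others in the source may bear on it.

In a functional assay on A2780 cells (Homo sapiens) for inhibition, read by sulforhodamine B assay (a lower number here means a stronger inhibitor of growth, a higher number a weaker inhibitor of growth), compound 1 `c1ccc(-c2ccc(-c3ccc(-c4nc5ccccc5[nH]4)cc3)cc2)cc1` gives 32100 nM. Compound 2 `Fc1ccc(-c2ccc(-c3ccc(-c4nc5ccccc5[nH]4)cc3)cc2)cc1` gives 48200 nM, level with compound 1 within the scatter, and compound 3 `COc1ccc(-c2ccc(-c3ccc(-c4nc5ccccc5[nH]4)cc3)cc2)cc1` gives 100000 nM, a higher number than both. Compound 4 `Clc1cccc(-c2ccc(-c3ccc(-c4nc5ccccc5[nH]4)cc3)cc2)c1` differs from compound 1 by chloro in place of hydrogen on an aromatic carbon. For the measured compounds named here, two measured steps bear on this: a 1.5-fold higher number from compound 1 to compound 2 (0.18 log units; within the scatter) for fluoro and a 3.1-fold higher number from compound 1 to compound 3 (0.49 log units; beyond the scatter) for methoxy. Going by the values given here, no chloro compound has been measured yet. A small move toward a higher number, or none beyond the scatter, is therefore expected. The expected change is a 1.4-fold higher number from compound 1 to compound 4 (0.15 log units; within the scatter). Compound 4 is estimated at 45000 nM, with an expected range of 20000 nM to 100000 nM.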

Compound 4, concentration for 50% growth inhibition: 31100 nM
Compound 4: the middle estimate sits 1.4-fold (0.16 log units) above what was measured, and the stated range covers the measured number.
By their numbers in this assay, from the lowest: compounds 4, 1 and 2 (each within the scatter of the next); then compound 3.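

Chloro on an aromatic carbon, meta to a large group, changes nothing beyond the scatter in this assay: a 1.0-fold lower number from compound 1 to compound 4 (0.01 log units; within the scatter). The change from 4-fluorophenyl to 3-chlorophenyl also stays within the scatter, with a 1.5-fold lower number from compound 2 to compound 4 (0.19 log units; within the scatter). The change from 4-methoxyphenyl to 3-chlorophenyl goes beyond it, with a 3.2-fold lower number from compound 3 to compound 4 (0.51 log units; beyond the scatter), so this place accepts chloro without the rise seen with methoxy.

Nothing shown gives a reason for these numbers. As far as these compounds go, whether an amine or a carboxylic acid in place of the chloro would keep the number level remains open.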